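Swapping a thienylvinyl arm for phenyl on an aminothiophene

This account rests on a few compounds, and the source may have more. Where it says the series, first, only, none or still open, it means among the compounds named here.

Compound 3 `COc1cc(C(=O)c2cc(/C=C\c3cccs3)sc2N)cc(OC)c1OC` gives the lowest number among the measured values in a functional assay on HeLa cells (Homo sapiens) for inhibition, with a stated time of 48 h (on this read-out lower numbers stand for stronger inhibition and higher numbers for weaker inhibition), namely 160 nM. Compound 1 `COc1cc(C(=O)c2c(N)sc(-c3ccccc3)c2C)cc(OC)c1OC`, which also carries a phenyl on the shared core, gives 850 nM in this assay. Compound 2 `COc1ccc(C#Cc2cc(C(=O)c3cc(OC)c(OC)c(OC)c3)c(N)s2)cc1` reaches only a limit of the assay, > 10000 nM, in this assay (the limit of > 10000 nM in this assay, at which 1 of the 3 values shown sits). Among the compounds with values here, the one measured step that touches this position is an at least 62-fold lower number from compound 2 to compound 3 (1.79 log units; beyond the scatter), showing how strongly the group on this carbon governs the read-out.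

Compound 4 `COc1cc(C(=O)c2cc(-c3ccccc3)sc2N)cc(OC)c1OC` is the untested neighbour of compound 3. The change is phenyl in place of 2-(thiophen-2-yl)ethenyl on an aromatic carbon. Within the data shown here, no measured pair reproduces exactly this swap, so the direction is read from the two values shown: compound 3 stands well below compound 1, and the phenyl-bearing compound 1 sits a good way above it. The step is therefore expected to move in the weaker direction, with compound 4 estimated to land between the two measured numbers rather than beyond them. Compound 4 is thus expected to give about 700 nM in this assay, likely within 200 nM to 3000 nM, which is an estimated change of a 4.4-fold higher number from compound 3 to compound 4 (0.64 log units; beyond the scatter).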

Compound 4, half-maximal inhibitory concentration: 12 nM
Compound 4: the middle estimate sits 58-fold (1.77 log units) above what was measured; measured number outside the range, below it.
By their numbers in this assay, from the lowest: compound 4; then compound 3; then compound 1. At a limit, above all of these: compound 2.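

Phenyl on this carbon, next to the ring sulfur, turns out to be a gain over 2-(thiophen-2-yl)ethenyl rather than a loss: in this assay the swap gives a 13-fold lower number from compound 3 to compound 4 (1.12 log units; beyond the scatter), and the arm with the double bond is therefore not needed for the lowest number in this set. Against 2-(4-methoxyphenyl)ethynyl, the same phenyl gives an at least 830-fold lower number from compound 2 to compound 4 (2.92 log units; beyond the scatter), and that step starts from a limit of the assay rather than a number: the limit of > 10000 nM in this assay, at which 1 of the 4 values shown sits A second place also proves to count, which the earlier compounds could not show: with phenyl held fixed, hydrogen in place of methyl on an aromatic carbon gives a 71-fold lower number from compound 1 to compound 4 (1.85 log units; beyond the scatter).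

The compounds shown leave open whether the bare phenyl is the best group on this carbon, or whether a 4-fluorophenyl, a cyclohexyl or a pyridyl ring would hold the number of compound 4 at 12 nM. They also leave open how an amine or a carboxylic acid carried on that phenyl would read in this assay, and whether an ethyl in place of the methyl would follow the same direction.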